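This account rests on a few compounds, and the source may have more. Where it says the series, first, only, none or still open, it means among the compounds named here.

Compound 1 `Cc1ccc(Oc2ccc(/C=N/n3c(C)nc4ccccc4c3=O)cc2)cc1`, compound 2 `Cc1nc2ccccc2c(=O)n1/N=C/c1ccc(Oc2ccc([N+](=O)[O-])cc2)cc1` and compound 3 `Cc1nc2ccccc2c(=O)n1/N=C/c1ccc(Oc2ccc(Br)cc2)cc1` share one core and differ only in the group on the far aromatic ring. In a physicochemical assay for lipophilicity, in phosphate buffer, measured as octanol-water partition (on this read-out higher numbers stand for higher lipophilicity and lower numbers for lower lipophilicity), compound 1 gives 4.32, compound 2 gives 4.01 and compound 3 gives 4.64. Compound 2 stands lowest of the three, with the step of a number 0.31 log units lower from compound 1 to compound 2 (beyond the scatter) and the step of a number 0.63 log units higher from compound 2 to compound 3 (beyond the scatter) both beyond the scatter, while the step of a number 0.32 log units higher from compound 1 to compound 3 (beyond the scatter) separates the other two.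

Compound 4 `O=c1c2ccccc2nc(-c2ccccc2)n1/N=C/c1ccc(Oc2ccc([N+](=O)[O-])cc2)cc1` keeps the nitro-bearing ring of compound 2 and changes the core instead: phenyl in place of methyl on an aromatic carbon. Going by the values given here, none of the three measured steps concerns this position; all three exchange the group on the far ring, so no measured step bears directly on the change. The expectation rests on the structural change alone, with six carbon atoms entering in one aromatic ring for one carbon leaving, and a step of a number 1.69 log units higher from compound 2 to compound 4 (beyond the scatter) in this assay is expected, upward and well beyond the scatter. For compound 4 the value in this assay is estimated at 5.7, within a range from 5.1 to 6.3.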

Compound 4, partition coefficient: 6.12
For compound 4 the middle estimate is 0.42 log units below the measured one, and the stated range covers the measured number.
By their numbers in this assay, from the lowest: compound 2; then compound 1; then compound 3; then compound 4.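

At this position on the core, between two ring nitrogen atoms, phenyl in place of methyl gives a large change in this assay and the step is a number 2.11 log units higher from compound 2 to compound 4 (beyond the scatter) in size. The exchanges on the far ring reach only a number 0.63 log units higher from compound 2 to compound 3 (beyond the scatter) at their widest, which is a modest step. The earlier compounds therefore gave no sign that a single change on the core could move this read-out further than any exchange on the far ring shown so far. Nothing available here accounts for the size of the step.

Going by these compounds, it remains open how an ethyl group, or a phenyl carrying an amine or a carboxylic acid, would behave at this position. On these data alone, it is also open whether the phenyl step would keep its size with methyl or bromo on the far ring instead of nitro.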